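Notes on the saturated ring carbon substituent, compound 3

The source may report more compounds than this note shows. Statements on the series, on what has been measured and on what is new or still open speak of the compounds shown alone.

Measured so far:
Compound 1, `Cc1cc(O)c(C2=NN(c3ccc(S(N)(=O)=O)cc3)C(c3ccccc3O)C2)cc1Cl` — in a functional assay on NCI-H322M cells (Homo sapiens) for antiproliferative activity, with a stated time of 48 h (on this read-out lower numbers stand for stronger inhibition of growth and higher numbers for weaker inhibition of growth), compound 1 gives 2500 nM.
Compound 2, `Cc1cc(O)c(C2=NN(c3ccc(S(N)(=O)=O)cc3)C(/C=C/c3ccccc3)C2)cc1Cl` — in this assay compound 2 gives 5730 nM.

Among the measured compounds shown here, compound 2 stands at the weaker end of the two numbers in hand; its nearest neighbour is compound 1, and the only measured step, a 2.3-fold higher number from compound 1 to compound 2 (0.36 log units; beyond the scatter), separates them.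

Compound 3, `COc1ccc(C2CC(c3cc(Cl)c(C)cc3O)=NN2c2ccc(S(N)(=O)=O)cc2)cc1OC`, is not yet measured. Its change from compound 2 is 3,4-dimethoxyphenyl in place of 2-phenylethenyl on a saturated ring carbon. For the measured compounds named here, the one step that bears on this is a 2.3-fold higher number from compound 1 to compound 2 (0.36 log units; beyond the scatter): there an aromatic ring on the saturated ring carbon was exchanged for the 2-phenylethenyl chain, and the number rose modestly. Compound 3 reverses that exchange in kind, returning an aromatic ring to the same carbon, though with 3,4-dimethoxy substitution rather than the 2-hydroxy of compound 1. Going by the values given here, no measured pair shows what that difference in substitution does, so the expectation rests on the return to an aryl group alone.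

Compound 3 is therefore expected to come in with a lower number than compound 2, a step of about a 1.9-fold lower number from compound 2 to compound 3 (0.28 log units; within the scatter) in this assay, landing near compound 1. The estimate for compound 3 is 3000 nM, with a range from 1200 nM to 8000 nM.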

Compound 3, concentration for 50% growth inhibition: 4450 nM
For compound 3 the middle estimate is 1.5-fold (0.17 log units) below the measured one, and the stated range covers the measured number.
By their numbers in this assay, from the lowest: compounds 1, 3 and 2 (each within the scatter of the next, the first and the last beyond it).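

In this assay the exchange of 2-phenylethenyl for 3,4-dimethoxyphenyl on the saturated ring carbon gives a 1.3-fold lower number from compound 2 to compound 3 (0.11 log units; within the scatter) and stays within the scatter, and the exchange of 2-hydroxyphenyl for 3,4-dimethoxyphenyl gives a 1.8-fold higher number from compound 1 to compound 3 (0.25 log units; within the scatter) and also stays within it. The one separation beyond the scatter at this position remains a 2.3-fold higher number from compound 1 to compound 2 (0.36 log units; beyond the scatter), so compound 3 sits unresolved from both neighbours, and the data give no sign that this carbon discriminates sharply among these three groups, of which only 3,4-dimethoxyphenyl brings hydrogen-bond acceptors. No measurement at hand accounts for these small differences.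

What a plain phenyl ring would give on this carbon stays open, so the separate contributions of the 2-hydroxy and the 3,4-dimethoxy substitution cannot be divided from the three compounds shown. Also open, as far as these compounds go, is whether a group of a different kind here, such as an amine, a carboxylic acid or a longer saturated chain, would move the number well beyond the narrow band these three compounds occupy.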